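Replacing the Aryl Amide with an Ester-Bearing Chain

This account rests on a few compounds, and the source may have more. Where it says the series, first, only, none or still open, it means among the compounds named here.

For the measured compounds named here, compound 2 `COc1ccc(C(=O)N(O)C(C)c2ccc3oc(-c4ccccc4)cc3c2)cc1OC` holds the lower of the two numbers measured so far. In an assay on RBL cells for inhibition of Polyunsaturated fatty acid 5-lipoxygenase (Rattus norvegicus) (a lower number here means a stronger inhibitor, a higher number a weaker inhibitor), compound 2 gives 200 nM, and compound 1 `CCCCCCCCCCc1cc2cc(C(C)N(O)C(C)=O)ccc2o1` gives 410 nM, a gap beyond the usual scatter. Compound 3 `CCOC(=O)CCC(=O)N(O)C(C)c1ccc2oc(-c3ccccc3)cc2c1` has not yet been tested; it differs from compound 2 by 2-(ethoxycarbonyl)ethyl in place of 3,4-dimethoxyphenyl on a carbonyl carbon. Going by the values given here, no measured pair shows the effect of such a change in this assay, so the expectation rests on compound 2 alone. A modest weakening is expected, a 2.0-fold higher number from compound 2 to compound 3 (0.30 log units; within the scatter). Compound 3 is estimated at 400 nM, with a likely range from 150 nM to 1200 nM.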

Compound 3, half-maximal inhibitory concentration: 50 nM
For compound 3 the middle estimate is 8.0-fold (0.90 log units) above the measured one; measured number below the stated range.
By their numbers in this assay, from the lowest: compound 3; then compound 2; then compound 1.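

On the carbonyl carbon whose other neighbour is the amide-type nitrogen, the ring of 3,4-dimethoxyphenyl proves unnecessary in this assay. The ringless 2-(ethoxycarbonyl)ethyl gives a 4.0-fold lower number from compound 2 to compound 3 (0.60 log units; beyond the scatter) and so lies beyond the scatter. This place therefore accepts an open ester-bearing chain, and that chain goes with the lower number here. Nothing at hand gives a reason for the step.

The compounds shown leave open whether the ester itself matters. A carboxylic acid or a longer chain on the same carbonyl carbon could settle this.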